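The compounds below may be only part of what the source reports. "The series", "measured", "known", "first", "only" and "open" are said of these compounds alone.

Working notes on the series, growth inhibition in a functional assay on HCT-15 cells (Homo sapiens) for cytotoxicity, read by sulforhodamine B assay, with a stated time of 72 h; a higher number here means a weaker inhibitor of growth, a lower number a stronger inhibitor of growth.

For the measured compounds named here, compound 1 `O=C(Nc1ccccc1O)C1CCc2ccccc2N1C(=O)c1ccc(Cl)cc1` gives 20200 nM in this assay, the highest of the two numbers so far; the nearest number is that of compound 3 `O=C(Nc1ccccc1C(F)(F)F)C1CCc2ccccc2N1C(=O)c1ccc(Cl)cc1`, which gives 839 nM in this assay, so that the step of a 24-fold lower number from compound 1 to compound 3 (1.38 log units; beyond the scatter) is a large one and lies beyond the scatter. Compound 2 `O=C(Nc1ccc(O)cc1)C1CCc2ccccc2N1` reaches only a limit of the assay and gives > 100000 nM in this assay, a limit as described by the limit of > 100000 nM in this assay, at which 1 of the 3 values shown sits.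

Compound 4 `O=C(Nc1ccccc1O)C1CCc2ccccc2N1` is not yet measured. It differs from compound 1 by hydrogen in place of (4-chlorophenyl)carbonyl on a nitrogen on an aromatic ring in a ring. Going by the values given here, no measured step follows this change directly. The pair compound 1 and compound 2 differs in two places at once, the acyl group on the ring nitrogen and the position of the hydroxy group, so their two values only show that the compound without the acyl group sits at the limit while compound 1 gives a number. On that basis compound 4 is expected to give a higher number than compound 1, with the step of a 5.0-fold higher number from compound 1 to compound 4 (0.69 log units; beyond the scatter) expected to run toward weaker growth inhibition, and a limit rather than a number is quite possible. The estimate for compound 4 in this assay is 100000 nM, within a range from 30000 nM to 300000 nM.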

Compound 4, concentration for 50% growth inhibition: 5610 nM
Compound 4: the middle estimate sits 18-fold (1.25 log units) above what was measured; the whole stated range lies above it.
By their numbers in this assay, from the lowest: compound 3; then compound 4; then compound 1. At a limit, above all of these: compound 2.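

In this assay, the step of a 3.6-fold lower number from compound 1 to compound 4 (0.56 log units; beyond the scatter) is modest but runs toward stronger growth inhibition, so with the hydroxy group of compound 1 kept in place, the (4-chlorophenyl)carbonyl on the ring nitrogen is not required for a measurable number, and hydrogen there is the better of the two. For the compounds shown here, this is the first direct reading of a change at this nitrogen, since the earlier measured step concerned only the trifluoromethyl and hydroxy groups on the aromatic carbon. Compound 2, which also carries hydrogen on the ring nitrogen, remains at a limit and gives no number to compare: the limit of > 100000 nM in this assay, at which 1 of the 4 values shown sits.

Still open, on these data alone, is whether hydrogen in place of (4-chlorophenyl)carbonyl moves the number in the same direction when trifluoromethyl replaces hydroxy, as in compound 3, so the effect of this change is known for one compound pair only. Also open, as far as these compounds go, is how smaller or differently charged groups on this nitrogen, such as an acetyl group, a methyl group or a chain ending in a carboxylic acid, would compare with hydrogen.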